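This account rests on a few compounds, and the source may have more. Where it says the series, first, only, none or still open, it means among the compounds named here.

Working notes on the series.

Compound 1 `FC(F)(F)c1cccc2cc(-c3nn[nH]n3)cnc12` and compound 2 `Fc1cccc2cc(-c3nn[nH]n3)cnc12` share a core; compound 3 `O=c1c(-c2nn[nH]n2)c[nH]c2c(F)cccc12` sits on a different core, and the difference between the two cores is not broken down here. In a functional assay on the whole organism (strain Sprague-Dawley) for inhibition, with Rattus norvegicus as the target (a higher number here means that more compound is needed for the effect, a lower number that less compound is needed), compound 1 gives < 25 mg/kg, which is a limit of the assay, so that the limit of < 25 mg/kg in this assay, at which 1 of the 3 values shown sits, is all that is known of it. In this assay compound 2 likewise gives > 10 mg/kg, a limit, so that the limit of > 10 mg/kg in this assay, at which 1 of the 3 values shown sits, is all that is known of it. In this assay, among the compounds with values here, compound 3 gives 0.625 mg/kg, the only plain number among the three.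

Within the data shown here, the one change made twice is trifluoromethyl in place of fluoro on an aromatic carbon: between the measured pair the step is a step that the limit leaves unreadable from compound 2 to compound 1, unreadable because the limit of < 25 mg/kg in this assay, at which 1 of the 3 values shown sits, and the limit of > 10 mg/kg in this assay, at which 1 of the 3 values shown sits, bound it from opposite sides. The same change carries compound 3 to compound 4 `O=c1c(-c2nn[nH]n2)c[nH]c2c(C(F)(F)F)cccc12`, with trifluoromethyl in place of fluoro on an aromatic carbon at the same place.

The measured pair gives no size for this change, so the expected step of a 1.3-fold higher number from compound 3 to compound 4 (0.11 log units; within the scatter) is set near zero with wide bounds. Compound 4 is therefore estimated at 0.8 mg/kg, expected between 0.2 mg/kg and 3 mg/kg.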

Compound 4, minimum effective dose: 0.156 mg/kg
Compound 4: middle estimate off by 5.1-fold (0.71 log units), on the high side; measured number outside the range, below it.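

On the core of compound 3, trifluoromethyl in place of fluoro on an aromatic carbon gives a 4.0-fold lower number from compound 3 to compound 4 (0.60 log units; beyond the scatter) in this assay, so the change has a readable size and direction on this core. The matching step from compound 2 to compound 1 cannot be read, as both compounds are known only through limits of the assay, so the result does not show whether the change carries over from one core to the other, or whether its size would be similar on both. Within the data shown here, the single readable step therefore describes the core of compound 3 alone, and nothing measured here bears on why the number falls.

Still open, as far as these compounds go, is whether the same change lowers the number on the core of compound 1, where only plain numbers could settle it. Also open, from the compounds shown here alone, is how an amine, a carboxylic acid or a longer chain at the same place would compare with fluoro and trifluoromethyl on either core.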